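This account rests on a few compounds, and the source may have more. Where it says the series, first, only, none or still open, it means among the compounds named here.

In a functional assay on MDA-MB-231 cells (Homo sapiens) for inhibition, read by MTT assay, with a stated time of 5 days (a lower number here means a stronger inhibitor, a higher number a weaker inhibitor), compound 1 `Cc1cc(Nc2nc(NCc3ccc(F)cc3)nc3[nH]ncc23)n[nH]1` gives 8410 nM, compound 2 `Cc1cc(Nc2nc(NCc3ccc(Br)cc3)nc3[nH]ncc23)n[nH]1` gives 1860 nM and compound 3 `Cc1cc(Nc2nc(NCc3ccc(F)cc3F)nc3[nH]ncc23)n[nH]1` gives 2670 nM. Compound 3 therefore stands level with compound 2, since a 1.4-fold higher number from compound 2 to compound 3 (0.16 log units; within the scatter) is within the scatter, and clear of compound 1, since a 3.1-fold lower number from compound 1 to compound 3 (0.50 log units; beyond the scatter) is beyond it. Compound 4 `Cc1cc(Nc2nc(NCc3ccc(C#N)cc3)nc3[nH]ncc23)n[nH]1` has not yet been measured. Its difference from compound 3 is 4-cyanophenyl in place of 2,4-difluorophenyl on a saturated chain carbon bound to a nitrogen on an aromatic ring. For the measured compounds named here, no measured compound carries a nitrile, so the only guide is the earlier changes to this aryl group. These were modest, with a 4.5-fold lower number from compound 1 to compound 2 (0.66 log units; beyond the scatter) the largest. Both compound 1 and compound 2 carry one ring substituent, as compound 4 does, and they differ from each other, so the direction is uncertain. A small step is expected in this assay, estimated at a 1.4-fold higher number from compound 3 to compound 4 (0.15 log units; within the scatter), and it is not expected to exceed the scatter. For compound 4 the estimated value is 3800 nM, with an expected range of 1500 nM to 9500 nM.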

Compound 4, half-maximal inhibitory concentration: 1360 nM
For compound 4 the middle estimate is 2.8-fold (0.45 log units) above the measured one, and the stated range ends above it.
By their numbers in this assay, from the lowest: compounds 4, 2 and 3 (each within the scatter of the next); then compound 1.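

Cyano at this position, as 4-cyanophenyl on a saturated chain carbon bound to a nitrogen on an aromatic ring, brings the first hydrogen-bond acceptor to this aryl group, yet in this assay it does not separate from the two nearest groups: a 2.0-fold lower number from compound 3 to compound 4 (0.29 log units; within the scatter) for the swap from 2,4-difluorophenyl, and a 1.4-fold lower number from compound 2 to compound 4 (0.14 log units; within the scatter) for cyano in place of bromo. Only the comparison with fluoro shows a clear gap, with a 6.2-fold lower number from compound 1 to compound 4 (0.79 log units; beyond the scatter), so among single substituents at this ring position bromo and cyano stand together and apart from fluoro. Nothing measured here explains this grouping.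

Still open, as far as these compounds go, is whether an amine or a carboxylic acid on this ring would stay level with cyano and bromo. Also open, from the compounds shown here alone, is whether a longer chain in place of the saturated chain carbon would keep these numbers.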